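The source may report more compounds than this note shows. Statements on the series, on what has been measured and on what is new or still open speak of the compounds shown alone.

The measured compounds:

Compound 1, `O=C1N=C(N2N=C(c3ccccc3)CC2c2ccccc2O)S/C1=C1/C(=O)Nc2ccccc21`: 17800 nM
Compound 2, `O=C1N=C(N2N=C(c3ccccc3)CC2c2ccccc2O)S/C1=C1/C(=O)Nc2ccc(Br)cc21`: 630 nM
Compound 3, `COc1ccc(C2CC(c3ccc4ccccc4c3)=NN2C2=NC(=O)/C(=C3\C(=O)Nc4ccccc43)S2)cc1`: 13600 nM

These three compounds were examined in a functional assay on cells (Cancer cell lines, Homo sapiens) for cytotoxicity, read by sulforhodamine B assay, with a stated time of 48 h; on this read-out lower numbers stand for stronger inhibition of growth and higher numbers for weaker inhibition of growth. Compound 1 and compound 2 share a core and differ in one place: bromo in place of hydrogen on an aromatic carbon. That change gave a 28-fold lower number from compound 1 to compound 2 (1.45 log units; beyond the scatter). Compound 3 rests on a different core; how the core of compound 3 differs from that of compound 1 is not broken down here. In this assay compound 3 and compound 1 give numbers that lie within the scatter of each other, while compound 2 stands well apart from both.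

Compound 4, `COc1ccc(C2CC(c3ccc4ccccc4c3)=NN2C2=NC(=O)/C(=C3\C(=O)Nc4ccc(Br)cc43)S2)cc1`, has not yet been measured. It stands to compound 3 as compound 2 stands to compound 1: bromo in place of hydrogen on an aromatic carbon. The place of the change is described in the same words for both pairs, so this is the same change on a different core. Because the step of a 28-fold lower number from compound 1 to compound 2 (1.45 log units; beyond the scatter) is large and beyond the scatter, a step of similar direction is expected for compound 4, and the estimated step is a 19-fold lower number from compound 3 to compound 4 (1.29 log units; beyond the scatter). Within the data shown here, since only one earlier instance of the change exists, the expectation is held with some caution and a wide range. The estimate for compound 4 in this assay is 700 nM. The expected range for compound 4 runs from 200 nM to 3000 nM.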

Compound 4, concentration for total growth inhibition: 330 nM
Beside the measured number, compound 4's estimate is 2.1-fold (0.33 log units) above it; the range from low to high includes it.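

In this assay, bromo in place of hydrogen on an aromatic carbon gave a 41-fold lower number from compound 3 to compound 4 (1.62 log units; beyond the scatter) and so carried over to a second core in the same direction, with a large step again. Set side by side, the two steps show that the size of the change was about the same on both cores: the same change on two cores in this assay, a 28-fold lower number (1.45 log units; beyond the scatter) from compound 1 to compound 2 and a 41-fold lower number (1.62 log units; beyond the scatter) from compound 3 to compound 4, 1.5-fold (0.16 log units) apart, within the scatter of two such steps. Among these compounds, this rests on only two cores, one place on the ring and a single assay, so it does not show that the step would hold on any other core or that the two cores respond identically beyond what these two pairs can resolve.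

The compounds shown leave open whether chloro, fluoro, a methoxy group or an amine at the same place would give a step like that of bromo, and whether bromo on another aromatic carbon would do the same. They also leave open what each of the differences between the two cores contributes by itself.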